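Swapping a Fluorophenyl for a Trimethoxyphenyl on the Hydrazone

The source may hold more compounds than are shown below. What is called first, only, known or untested is meant among the compounds shown, and "the series" means these compounds.

Compound 1 `CNc1nc(C(F)(F)F)c(C(=O)N/N=C/c2cccc(C(F)(F)F)c2)s1`: > 100 ug/mL
Compound 2 `Cc1nc(N(C)C(=O)NC(=O)c2c(F)cccc2F)sc1C(=O)N/N=C/c1ccccc1F`: > 100 ug/mL
Compound 3 `Cc1nc(N(C)C(=O)NC(=O)c2c(F)cccc2F)sc1C(=O)N/N=C/c1cc(C(F)(F)F)cc(C(F)(F)F)c1`: 11.4 ug/mL

All three were tested in a functional assay on HepG2 cells (Homo sapiens) for inhibition, read by MTT assay, with a stated time of 72 h; a higher number here means a weaker inhibitor, a lower number a stronger inhibitor. Compound 1 reaches only the assay limit, > 100 ug/mL. Compound 2 also gives only a limit, > 100 ug/mL, so it sits at the limit of > 100 ug/mL in this assay, at which 2 of the 3 values shown sit, together with compound 1. Compound 3 gives a real number, 11.4 ug/mL. Compound 4 `COc1cc(/C=N/NC(=O)c2sc(N(C)C(=O)NC(=O)c3c(F)cccc3F)nc2C)cc(OC)c1OC` is not yet measured; it differs from compound 2 in one place: 3,4,5-trimethoxyphenyl in place of 2-fluorophenyl on a carbon with a double bond to nitrogen. For the measured compounds named here, no measured pair isolates this change, so its size is uncertain. Compound 3 carries another substituted ring on the carbon with a double bond to nitrogen and gives 11.4 ug/mL. On that basis compound 4 is expected to gain by about an at least 2.5-fold lower number from compound 2 to compound 4 (0.39 log units; beyond the scatter). The estimate for compound 4 is 40 ug/mL, within 10 ug/mL to 150 ug/mL.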

Compound 4, half-maximal inhibitory concentration: > 100 ug/mL
Compound 4 was reported as a limit (the forecaster's own chance of this, stated with the estimate: 45%); at least 2.5-fold (0.39 log units) between middle value and limit.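

Compound 2 and compound 4 both stop at a limit rather than a real number, so no step can be read between them: the limit of > 100 ug/mL in this assay, at which 3 of the 4 values shown sit.

The compounds shown leave open whether 3,4,5-trimethoxyphenyl in place of 2-fluorophenyl changes the inhibition at all, and by how much.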